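The source may report more compounds than this note shows. Statements on the series, on what has been measured and on what is new or still open speak of the compounds shown alone.

Measured in a functional assay on Raji cells (Homo sapiens) for cytotoxicity, with a stated time of 72 h; a higher number here means that more compound is needed for the effect, a lower number that less compound is needed:
- compound 1 `C=C[C@@](C)(/C=C/c1ccc(O)cc1)CCC=O`: > 26000 nM
- compound 2 `C=C[C@@](C)(/C=C/c1ccc(O)cc1)CCCO`: > 26000 nM
- compound 3 `C=C[C@@](C)(/C=C/c1ccc(O)cc1)CC/C=C/C(=O)c1ccccc1`: > 26000 nM

All three entries are limits of the assay, not numbers. Compound 3 gives > 26000 nM, and this too is only a limit. Within the data shown here, the series so far comes down to the limit of > 26000 nM in this assay, at which 3 of the 3 values shown sit.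

Compound 4 `C=C[C@@](C)(/C=C/c1ccc(O)cc1)CC/C=C/C#N` carries cyano in place of benzoyl on a double-bonded chain carbon bound to a double-bonded chain carbon.

Among the measured compounds shown here, the only measured step available is a step that the two limits leave unreadable from compound 1 to compound 2. It offers no size to carry over, and it concerns a different change. With no readable step to go on, no step beyond the scatter is expected in this assay, in either direction. The step expected is a step that the limit leaves unreadable from compound 3 to compound 4. For compound 4 the estimate is 30000 nM, with an expected range of 15000 nM to 60000 nM. The most likely outcome is that the assay again reports only a limit.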

Compound 4, half-maximal effective concentration: > 26000 nM
Compound 4: a limit, no number; the forecaster's own chance of this, stated with the estimate: 85%; the middle value is on the limit's open side.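

In this assay compound 4 gives > 26000 nM, which is a limit and not a number. No step can be read between compound 4 and compound 1, compound 2 or compound 3. The compounds shown leave open what change, if any, would give a measurable value, as the series stays at one limit: the limit of > 26000 nM in this assay, at which 4 of the 4 values shown sit.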